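Chalcone-pyrazole series: aryl ketone exchange at the carbonyl

The source may hold more compounds than are shown below. What is called first, only, known or untested is meant among the compounds shown, and "the series" means these compounds.

Two members of the series carry measurements in a functional assay on NCI-H460 cells (Homo sapiens) for inhibition, read by sulforhodamine B assay, with a stated time of 48 h; on this read-out higher numbers stand for weaker inhibition of growth and lower numbers for stronger inhibition of growth. Compound 1 `COc1ccc(-c2cc(/C=C/C(=O)c3ccc(N)cc3)[nH]n2)cc1` gives 4950 nM in this assay. Going by the values given here, compound 2 `COc1cc(-c2cc(/C=C/C(=O)c3ccc(N)cc3)[nH]n2)cc(OC)c1OC` gives 5100 nM in this assay, and that number lies within the usual scatter of the number for compound 1, so the two cannot be told apart on this read-out; no step between them is counted.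

Compound 3 `COc1cc(-c2cc(/C=C/C(=O)c3ccc(Cl)c(Cl)c3)[nH]n2)cc(OC)c1OC` has not yet been measured in this assay. It differs from compound 2 in one place: 3,4-dichlorophenyl in place of 4-aminophenyl on a carbonyl carbon. Among the compounds with values here, no measured pair shows what such an exchange does in this assay, so the direction of any shift is not supported by data. The working expectation is a step from compound 2 to compound 3 of a 1.5-fold lower number from compound 2 to compound 3 (0.16 log units; within the scatter), of moderate size and no more than that. Compound 3 is estimated at 3500 nM in this assay, with a plausible range from 1000 nM to 12000 nM.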

Compound 3, concentration for total growth inhibition: 36600 nM
Estimate against measurement, compound 3: 10-fold (1.02 log units) below, outside the stated range (above it).
By their numbers in this assay, from the lowest: compounds 1 and 2 (each within the scatter of the next); then compound 3.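

In this assay the aryl group on a carbonyl carbon is a position where the number moves: 3,4-dichlorophenyl in place of 4-aminophenyl gives a 7.2-fold higher number from compound 2 to compound 3 (0.86 log units; beyond the scatter) and this step lies beyond the scatter. Compound 1 and compound 2 both carry 4-aminophenyl and could not be told apart, so this single pair is the only measured sign that the series responds to a change in the compound. Nothing measured here explains the step.

The exchange removes 4-aminophenyl and brings in two chlorines at once, so the compounds shown cannot separate the loss of the amine from the entry of the halogens. Plain phenyl, 4-chlorophenyl and 4-hydroxyphenyl on the same carbonyl carbon would divide those two contributions, and whether the step carries over to the core of compound 1 remains open.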